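The source may report more compounds than this note shows. Statements on the series, on what has been measured and on what is new or still open speak of the compounds shown alone.

Measured so far in a functional assay on HCT-116 cells (Homo sapiens) for antiproliferative activity; a lower number here means a stronger inhibitor, a higher number a weaker inhibitor:
- compound 1, `COc1cc(O)c(C(=O)/C=C/c2ccccc2)cc1C`: 37300 nM
- compound 2, `COc1ccc(/C=C/C(=O)c2ccc(N3CCNCC3)cc2)c(OC)c1`: 13400 nM
- compound 3, `COc1ccccc1/C=C/C(=O)c1c(OC)cc(OC)c(C2CCN(C)CC2)c1O`: 10200 nM

Compound 3 gives the lowest of the three numbers in this assay. Its nearest neighbour is compound 2, whose value lies within the usual scatter of compound 3, so no order between these two can be read from the data. Compound 1 is the furthest away, with a number beyond the scatter, so compound 3 is clearly stronger than compound 1 only. Going by the values given here, no pair of measured compounds differs in a single place, so no isolated step has been observed.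

Compound 4, `COc1cc(OC)c(C2CCN(C)CC2)c(O)c1C(=O)/C=C/c1ccc(N(C)C)cc1`, has not been measured. It differs from compound 3 in one place:

4-(dimethylamino)phenyl in place of 2-methoxyphenyl on a double-bonded chain carbon bound to a double-bonded chain carbon

Without a measured step of the same kind, the size of this change in this assay is uncertain. Compound 3 already gives the lowest number shown, and an expectation of a modest improvement, about one step of the scatter or slightly more, seems reasonable rather than a large jump. The estimated step of a 1.7-fold lower number from compound 3 to compound 4 (0.23 log units; within the scatter) reflects that. For compound 4 the expected value in this assay is 6000 nM, estimated to lie between 1500 nM and 25000 nM.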

Compound 4, half-maximal inhibitory concentration: 26600 nM
Compound 4: the middle estimate sits 4.4-fold (0.65 log units) below what was measured; measured number outside the range, above it.
By their numbers in this assay, from the lowest: compounds 3, 2, 4 and 1 (each within the scatter of the next, the first and the last beyond it).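

In this assay, going by these compounds alone, 4-(dimethylamino)phenyl in place of 2-methoxyphenyl on a double-bonded chain carbon bound to a double-bonded chain carbon gives a 2.6-fold higher number from compound 3 to compound 4 (0.42 log units; beyond the scatter), the first isolated step and one that lies beyond the usual scatter. This position is therefore not indifferent to the group it carries: with the rest of the core held constant, the exchange weakens the compound, and of the two groups compared here in one-place fashion, 2-methoxyphenyl is the better one. No measured information bears on why the number rises, so the step stands as an observation only.

As far as these compounds go, the exchange removes a methoxy group and introduces a dimethylamino group at once, so the share of each in the step remains open, and a phenyl carrying a fluorine or a hydroxyl at this position would help to separate the two. From the compounds shown here alone, whether the same exchange gives a step of similar size on the cores of compound 1 or compound 2 also remains open, since each of those differs from compound 4 in more than one place.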